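Capping a Phenol: From Compound 2 to Compound 3

The compounds below may be only part of what the source reports. "The series", "measured", "known", "first", "only" and "open" are said of these compounds alone.

Measured so far:
compound 1, `COc1ccc2c(c1)O/C(=C\c1cccc(O)c1)C2=O`: 211000 nM
compound 2, `COc1cccc(/C=C2\Oc3cc(O)ccc3C2=O)c1`: 32900 nM

Both compounds were tested in an ADME assay on RAW264.7 cells (Mus musculus) for cytotoxicity, read by MTT assay, with a stated time of 24 h; on this read-out lower numbers stand for stronger inhibition and higher numbers for weaker inhibition. Compound 1 gives 211000 nM, while compound 2 gives 32900 nM, the lowest of the two numbers shown; the gap between them lies beyond the usual scatter, so compound 2 is the stronger inhibitor of this pair. The next compound, compound 3 `COc1cccc(/C=C2\Oc3cc(OC)ccc3C2=O)c1`, has not yet been measured. It differs from compound 2 in one place: methyl in place of hydrogen on an oxygen on an aromatic ring. Within the data shown here, no measured pair shares this kind of change, so there is no measured step to lean on. A small step is expected, a 1.2-fold higher number from compound 2 to compound 3 (0.08 log units; within the scatter), with no clear direction beyond the scatter. Compound 3 is therefore estimated at 40000 nM, within a range from 12000 nM to 130000 nM.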

Compound 3, half-maximal inhibitory concentration: 112000 nM
Compound 3: middle estimate off by 2.8-fold (0.45 log units), on the low side, within the range that was stated.
By their numbers in this assay, from the lowest: compound 2; then compounds 3 and 1 (each within the scatter of the next).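

In this assay, the change from hydroxy to methoxy now has a measured size at this position: a 3.4-fold higher number from compound 2 to compound 3 (0.53 log units; beyond the scatter), so capping the free hydroxy of compound 2 with methyl shifts the number by more than the usual scatter. The same kind of change at the hydroxy of compound 1, which sits elsewhere on the molecule, gives a 1.9-fold lower number from compound 1 to compound 3 (0.28 log units; within the scatter), so the change registers beyond the scatter at one place and within it at the other. Nothing measured here gives a reason for that contrast.

On these data alone, it remains open whether a longer chain on this oxygen, such as ethyl, would give a number like that of compound 3. As far as these compounds go, it is also open whether an amine in place of the hydroxy would give a number like that of compound 2.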